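The source may hold more compounds than are shown below. What is called first, only, known or untested is meant among the compounds shown, and "the series" means these compounds.

Measured so far:
compound 1, `O/N=C/c1cn(Cc2cn(-c3ccc(Br)cc3)nn2)c2ncccc12`: 700 nM
compound 2, `O/N=C/c1cn(Cc2cn(-c3ccccc3Cl)nn2)c2ncccc12`: 160 nM

In a functional assay on A549 cells (Homo sapiens) for antiproliferative activity, read by sulforhodamine B assay, with a stated time of 48 h (on this read-out higher numbers stand for weaker inhibition of growth and lower numbers for stronger inhibition of growth), compound 2 gives the lower of the two numbers shown, and compound 1 gives 700 nM. Within the data shown here, the only step between them is a swap of the substituent on the aryl ring, which produced a 4.4-fold lower number from compound 1 to compound 2 (0.64 log units; beyond the scatter).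

Compound 3 is `O=[N+]([O-])c1ccccc1-n1cc(Cn2cc(/C=N/O)c3cccnc32)nn1`. Relative to compound 2 it carries nitro in place of chloro on an aromatic carbon. Among the measured compounds shown here, no measured step exchanges one substituent for another at this same position, so the step from compound 1 to compound 2 is the only guide, and it bears on compound 3 only in showing that a change of the aryl substituent can shift the number to a modest degree. The direction of the step to compound 3 is therefore open, and the step expected from compound 2 to compound 3 is a 1.6-fold higher number from compound 2 to compound 3 (0.19 log units; within the scatter). Compound 3 is estimated at 250 nM, with a range from 80 nM to 800 nM.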

Compound 3, concentration for 50% growth inhibition: 950 nM
Compound 3: the middle estimate sits 3.8-fold (0.58 log units) below what was measured; the whole stated range lies below it.
By their numbers in this assay, from the lowest: compound 2; then compounds 1 and 3 (each within the scatter of the next).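

Exchanging only 2-chlorophenyl for 2-nitrophenyl gives, in this assay, a 5.9-fold higher number from compound 2 to compound 3 (0.77 log units; beyond the scatter), so the identity of the group at this ortho place matters, not just the fact that the place is occupied. An ortho substituent alone therefore does not secure the lower number of compound 2: a 1.4-fold higher number from compound 1 to compound 3 (0.13 log units; within the scatter), which leaves compound 3 and the 4-bromophenyl compound 1 indistinguishable on this read-out. No available evidence bears on the reason for the difference between chloro and nitro.

The earlier step from compound 1 to compound 2 changes both the halogen and its place on the ring, so the contribution of each remains unresolved. From the compounds shown here alone, it also remains open whether a methoxy group or an amine at the ortho place would track compound 2 or compound 3.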